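Removing a Methoxy Group from a Bis-Furan Amidine

This account rests on a few compounds, and the source may have more. Where it says the series, first, only, none or still open, it means among the compounds named here.

Two compounds that carry an amidine on a shared core have been tested in a functional assay on A498 cells (Homo sapiens) for inhibition, read by sulforhodamine B assay, with a stated time of 48 h; on this read-out higher numbers stand for weaker inhibition of growth and lower numbers for stronger inhibition of growth. Compound 1 `N=C(N)c1ccc(-c2ccc(-c3cc(Cl)cc(Cl)c3)s2)s1` gives 1530 nM in this assay. Compound 2 `COc1ccc(-c2ccc(-c3ccc(C(=N)N)o3)o2)cc1` gives 1760 nM in this assay. Compound 2 holds the higher of the two numbers, but its gap to compound 1 lies within the scatter of the measurement, so the two show about the same inhibition of growth.

Compound 3 `N=C(N)c1ccc(-c2ccc(-c3ccccc3)o2)o1` is the compound still to be tested. It differs from compound 2 in one place: hydrogen in place of methoxy on an aromatic carbon. Among the compounds with values here, no pair of measured compounds shows what this change does here, so nothing known points to a large shift in either direction. Compound 1 and compound 2, though quite different in make-up, sit close together, which gives no hint of large moves from a small change at the outer ring. The step from compound 2 to compound 3 is therefore expected to be a 1.2-fold higher number from compound 2 to compound 3 (0.08 log units; within the scatter), not beyond the scatter. Compound 3 is estimated to give 2100 nM in this assay, with a range from 900 nM to 5000 nM.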

Compound 3, concentration for 50% growth inhibition: 3030 nM
For compound 3 the middle estimate is 1.4-fold (0.16 log units) below the measured one; measured number inside the range.
By their numbers in this assay, from the lowest: compounds 1, 2 and 3 (each within the scatter of the next).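

Replacing methoxy with hydrogen on the outer six-membered aromatic ring, at the carbon para to a large group, gives a 1.7-fold higher number from compound 2 to compound 3 (0.24 log units; within the scatter) in this assay, the first direct reading of this change among these compounds. The step stays within the scatter, so this single pair gives no sign that methoxy at this place matters for inhibition of growth: compound 2 and compound 3 show about the same effect, and the pair cannot separate a small real difference from the noise of repeat measurements. Nothing on hand offers an explanation for this reading, and the step alone cannot supply one.

Still open, on these data alone, is whether a different group at this same place, such as an amine, a hydroxyl group, a chlorine atom or a longer chain like butoxy, would move the number beyond the scatter in either direction. Also open, as far as these compounds go, is whether replacing methoxy with hydrogen would give a similar step on a different core, such as the core of compound 1, since a single pair on one core cannot show how far the result carries.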